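A few compounds are considered here, and "the series" means these few. Any claim that something is new, unique, unknown or untested is made for them only; others in the source may bear on it.

Compound 1 `CC(=O)Nc1nc2ccc(-c3cnc(Cl)c(NS(=O)(=O)c4ccc(F)cc4)c3)cn2n1`, compound 2 `COc1ncc(-c2ccc3nc(NC(C)=O)nn3c2)cc1NS(=O)(=O)c1ccc(F)cc1` and compound 3 `COc1ncc(-c2ccc3nc(NC(=O)C4CC4)nn3c2)cc1NS(=O)(=O)c1ccc(F)cc1` share one core and were tested in a functional assay on HCT-116 cells (Homo sapiens) for antiproliferative activity, read by MTT assay, with a stated time of 48 h; a lower number here means a stronger inhibitor, a higher number a weaker inhibitor. In this assay compound 1 gives 9230 nM, compound 2 gives 850 nM, and compound 3 gives 1740 nM. Among these three numbers compound 3 stands second highest: it is separated from compound 2 by a 2.0-fold higher number from compound 2 to compound 3 (0.31 log units; beyond the scatter), and from compound 1 by a larger gap. The step of an 11-fold lower number from compound 1 to compound 2 (1.04 log units; beyond the scatter) is the largest change shown.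

Compound 4 `O=C(Nc1nc2ccc(-c3cnc(Cl)c(NS(=O)(=O)c4ccc(F)cc4)c3)cn2n1)C1CC1` is made from compound 3 by a single change: chloro in place of methoxy on an aromatic carbon. This is the exact reverse of the change between compound 1 and compound 2, where chloro was replaced by methoxy and the number fell by an 11-fold lower number from compound 1 to compound 2 (1.04 log units; beyond the scatter). The amide change, a 2.0-fold higher number from compound 2 to compound 3 (0.31 log units; beyond the scatter), was modest by comparison. Compound 4 is therefore expected to show a large rise, estimated as a 10-fold higher number from compound 3 to compound 4 (1.01 log units; beyond the scatter) in this assay. Compound 4 is expected to give about 18000 nM, with a plausible range from 8000 nM to 40000 nM.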

Compound 4, half-maximal inhibitory concentration: 9980 nM
Compound 4: middle estimate off by 1.8-fold (0.26 log units), on the high side; measured number inside the range.
By their numbers in this assay, from the lowest: compound 2; then compound 3; then compounds 1 and 4 (each within the scatter of the next).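

Putting chloro back in place of methoxy on this carbon, next to the ring nitrogen, also weakens the cyclopropyl amide, with a 5.7-fold higher number from compound 3 to compound 4 (0.76 log units; beyond the scatter) in this assay. The advantage of methoxy over chloro is therefore not confined to the methyl amide, and the two steps agree in size: the same change on two cores in this assay, an 11-fold lower number (1.04 log units; beyond the scatter) from compound 1 to compound 2 and a 5.7-fold lower number (0.76 log units; beyond the scatter) from compound 4 to compound 3, 1.9-fold (0.28 log units) apart, within the scatter of two such steps With chloro on this carbon, the methyl and cyclopropyl amides cannot be told apart, with a 1.1-fold higher number from compound 1 to compound 4 (0.03 log units; within the scatter), and the amide swap gives a comparable result on both cores: the same change on two cores in this assay, a 2.0-fold higher number (0.31 log units; beyond the scatter) from compound 2 to compound 3 and a 1.1-fold higher number (0.03 log units; within the scatter) from compound 1 to compound 4, 1.9-fold (0.28 log units) apart, within the scatter of two such steps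

The compounds shown leave open how an ethoxy group, a hydroxyl or an amine on this carbon would compare with methoxy. They also leave open whether a longer chain on the amide carbonyl would separate from methyl and cyclopropyl.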